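Chloro to Methylsulfanyl: What to Expect for Compound 4

A few compounds are considered here, and "the series" means these few. Any claim that something is new, unique, unknown or untested is made for them only; others in the source may bear on it.

Compound 1, `CC(C)(C)c1cc(C(=O)N2CCc3ccccc32)cc(C#N)c1O`: in an assay on tissue (RPTEC cells) for inhibition of solute carrier family 22 member 12 (Homo sapiens), read by scintillation counting, with stated times of 15 min and 2 h (on this read-out lower numbers stand for stronger inhibition and higher numbers for weaker inhibition), compound 1 gives 31600 nM.
Compound 2, `N#Cc1cc(C(=O)N2CCc3ccccc32)cc(C2CC2)c1O`: compound 2 gives 8800 nM.
Compound 3, `N#Cc1cc(C(=O)N2CS(=O)(=O)c3ccccc32)cc(Cl)c1O`: compound 3 gives > 100000 nM, which is a limit of the assay and not a number.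

Compound 3 therefore sits at the limit of > 100000 nM in this assay, at which 1 of the 3 values shown sits, the weakest position the read-out can report. Compound 4, `CSc1cc(C(=O)N2CS(=O)(=O)c3ccccc32)cc(C#N)c1O`, differs from it by methylsulfanyl in place of chloro on an aromatic carbon. For the measured compounds named here, no measured pair carries this change. Going by the values given here, the one measured step, a 3.6-fold lower number from compound 1 to compound 2 (0.56 log units; beyond the scatter), alters the group on the same kind of aromatic carbon but on another core and with other groups, and it is modest. The step from compound 3 to compound 4 is thus expected to be a number no higher from compound 3 to compound 4 (the limit leaves the size open), with no clear direction. Compound 4 is expected at 100000 nM, between 30000 nM and 300000 nM.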

Compound 4, half-maximal inhibitory concentration: 7100 nM
Estimate against measurement, compound 4: 14-fold (1.15 log units) above; measured number outside the range, below it.
By their numbers in this assay, from the lowest: compounds 4 and 2 (each within the scatter of the next); then compound 1. At a limit, above all of these: compound 3.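

On the core of compound 3, the aromatic carbon ortho to a hydroxy group responds strongly in this assay: methylsulfanyl in place of chloro gives an at least 14-fold lower number from compound 3 to compound 4 (1.14 log units; beyond the scatter). For the compounds shown here, the only earlier step at this kind of carbon was modest and lay on another core. Compound 3 stands at a limit of the assay, so this step has only a minimum size: the limit of > 100000 nM in this assay, at which 1 of the 4 values shown sits.

As far as these compounds go, whether methylsulfanyl would act likewise on the core of compound 1 stays open. So does how a methoxy group or an amine would read at this position.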